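A few compounds are considered here, and "the series" means these few. Any claim that something is new, unique, unknown or untested is made for them only; others in the source may bear on it.

Compound 1, `O=C1C(=O)N(Cc2ccc(Oc3nccs3)cc2)c2ccc(OC(F)(F)F)cc21`: 2800 nM
Compound 2, `O=C1C(=O)N(Cc2ccc(Oc3ccccn3)cc2)c2ccc(OC(F)(F)F)cc21`: 3200 nM

Both compounds were tested in a functional assay on CHO cells for positive allosteric modulation of muscarinic acetylcholine receptor M5 (Homo sapiens), read by FLIPR and calcium flux, with a stated time of 1 h; a lower number here means that less compound is needed, a higher number that more compound is needed for the effect. Compound 2 and compound 1 lie within the scatter of each other, as the step of a 1.1-fold higher number from compound 1 to compound 2 (0.06 log units; within the scatter) shows; that step came with pyridin-2-yl in place of 1,3-thiazol-2-yl on an oxygen on an aromatic ring. Compound 3, `O=C1C(=O)N(Cc2ccc(-c3ccncc3)cc2)c2ccc(OC(F)(F)F)cc21`, differs from compound 2 by pyridin-4-yl in place of (pyridin-2-yl)oxy on an aromatic carbon. Among the compounds with values here, no measured step covers this change; the only measured step exchanged the ring on the oxygen and stayed within the scatter. Compound 3 is therefore expected to give about 4000 nM in this assay, with a range from 1500 nM to 12000 nM. The expected step is a 1.3-fold higher number from compound 2 to compound 3 (0.10 log units; within the scatter), nothing clearly beyond the scatter.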

Compound 3, half-maximal effective concentration: 2800 nM
Compound 3: the middle estimate sits 1.4-fold (0.15 log units) above what was measured; the range from low to high includes it.
By their numbers in this assay, from the lowest: compounds 1, 3 and 2 (each within the scatter of the next).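

Replacing (pyridin-2-yl)oxy with pyridin-4-yl on the aromatic carbon gave a 1.1-fold lower number from compound 2 to compound 3 (0.06 log units; within the scatter), and replacing (1,3-thiazol-2-yl)oxy with the same group gave no change at the digits printed from compound 1 to compound 3 (within the scatter). The earlier compounds shown here had varied only the ring on the oxygen, whereas these steps show that, at this place para to a large group, losing the oxygen and changing the ring together stays within the scatter. No evidence here accounts for these small steps. From the compounds shown here alone, whether an amine or a carboxylic acid at this place would move the number beyond the scatter remains open. So does whether directly attached pyridin-3-yl would match pyridin-4-yl.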